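An aromatic ring in place of a fluorinated chain

This account rests on a few compounds, and the source may have more. Where it says the series, first, only, none or still open, it means among the compounds named here.

Within the data shown here, compound 1 `Cc1nc(S(C)(=O)=O)ccc1Oc1ncnc(OC2CCN(C(=O)O[C@H](C)CF)CC2)c1F` is one of three compounds measured in a functional assay on isolated protein for inhibition of Glucose-dependent insulinotropic receptor (Rattus norvegicus), read by HTRF and cAMP accumulation; a higher number here means a larger maximal response, a lower number a smaller maximal response. In this assay compound 1 gives 79%, the second highest of the three numbers. Compound 2 `Cc1nc(S(C)(=O)=O)ccc1Oc1ncnc(OC2CCN(C(=O)O[C@H](C)C(F)(F)F)CC2)c1F` gives 85%; the step of a number 6 percentage points higher from compound 1 to compound 2 (within the scatter) lies within the scatter, so these two cannot be ordered. Compound 3 `Cc1nc(S(C)(=O)=O)ccc1Oc1ncnc(OC2CCN(C(=O)OC3COC3)CC2)c1F` gives 66%, with a number 13 percentage points lower from compound 1 to compound 3 (beyond the scatter) and a number 19 percentage points lower from compound 2 to compound 3 (beyond the scatter), both modest losses.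

Compound 4 `Cc1nc(S(C)(=O)=O)ccc1Oc1ncnc(OC2CCN(C(=O)c3noc(C(C)C)n3)CC2)c1F` has not yet been measured. It differs from compound 1 as follows: a group of 8 heavy atoms (5 carbon, 2 nitrogen, 1 oxygen; one five-membered aromatic ring with 3 hetero atoms) in place of a group of 5 heavy atoms (3 carbon, 1 oxygen, 1 fluorine; no ring), on a carbonyl carbon. Among the measured compounds shown here, none of the measured steps changes the same kind of group: compounds 1, 2 and 3 all keep an oxygen on the carbonyl carbon and vary only what hangs from it, whereas compound 4 carries an aromatic ring directly on that carbon. For the measured compounds named here, the only guide is that the single change introducing a ring, from compound 1 to compound 3, lowered the maximal response modestly. A small loss is therefore expected, a number 9 percentage points lower from compound 1 to compound 4 (within the scatter), with wide uncertainty. Compound 4 is expected to give 70%, within 52% to 88%.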

Compound 4, largest response reached (reported as efficacy), in percent of the reference or control that the assay uses: 81%
The estimate for compound 4 lay 11 percentage points below the measured number, and the stated range covers the measured number.
By their numbers in this assay, from the lowest: compound 3; then compounds 1, 4 and 2 (each within the scatter of the next).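

The carbonyl carbon on the amide-type nitrogen in a ring need not carry an oxygen: with 5-isopropyl-1,2,4-oxadiazol-3-yl attached directly, this assay shows a number 2 percentage points higher from compound 1 to compound 4 (within the scatter) and a number 4 percentage points lower from compound 2 to compound 4 (within the scatter). A ring at this place therefore does not by itself go with a smaller maximal response, as there is a number 15 percentage points higher from compound 3 to compound 4 (beyond the scatter), and among the ring-bearing groups only the (oxetan-3-yl)oxy group of compound 3 sits beyond the scatter from the others. No measurement at hand explains the gap between these two ring-bearing groups.

The compounds shown hold only one aromatic ring on this carbonyl carbon, so it remains open whether a plain phenyl ring would keep the response. On these data alone, it is also open whether the isopropyl group matters, which a cyclopropyl or methyl group on the same 1,2,4-oxadiazole would test.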